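From Oxazolylthiophene to a Chlorinated Bicycle on the Sulfonamide

The source may hold more compounds than are shown below. What is called first, only, known or untested is meant among the compounds shown, and "the series" means these compounds.

Three compounds built on one shared core were tested in an assay on isolated protein for inhibition of coagulation factor X (Oryctolagus cuniculus), tested at 1 uM; a lower number here means less inhibition, a higher number more inhibition at the concentration tested (going by the name of the read-out). Compound 1 `CC(C)(C)c1ccc(S(=O)(=O)N[C@H]2CCN(Cc3cc4c[nH]ccc-4n3)C2=O)cc1` gives 14%, compound 2 `O=C1[C@@H](NS(=O)(=O)c2cc3c(Cl)nccc3s2)CCN1Cc1cc2c[nH]ccc-2n1` gives 35%, and compound 3 `O=C1[C@@H](NS(=O)(=O)c2ccc(-c3ccon3)s2)CCN1Cc1cc2c[nH]ccc-2n1` gives 17%. Compound 3 thus stands second highest of the three, close to compound 1 and well under compound 2. Compound 4 `O=C1[C@@H](NS(=O)(=O)c2cc3ccnc(Cl)c3s2)CCN1Cc1cc2c[nH]ccc-2n1` differs from compound 3 by a group of 10 heavy atoms (7 carbon, 1 nitrogen, 1 sulfur, 1 chlorine; one five-membered aromatic ring with 1 hetero atom, one six-membered aromatic ring with 1 hetero atom) in place of a group of 10 heavy atoms (7 carbon, 1 nitrogen, 1 oxygen, 1 sulfur; one five-membered aromatic ring with 1 hetero atom, one five-membered aromatic ring with 2 hetero atoms), on a sulfonyl sulfur. Among the compounds with values here, two measured steps bear on this change: a number 21 percentage points higher from compound 1 to compound 2 (beyond the scatter) and a number 18 percentage points lower from compound 2 to compound 3 (beyond the scatter), both placing the chlorine-bearing group on the sulfonyl sulfur above the alternatives in this assay, although compound 4 is not identical to compound 2. A modest upward step is therefore expected, a number 13 percentage points higher from compound 3 to compound 4 (beyond the scatter). For compound 4 the estimated inhibition is 30%, with a range from 15% to 48%.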

Compound 4, a percentage reported as inhibition, at one concentration (the size of the read-out at that concentration, not a potency): 25%
For compound 4 the middle estimate is 5 percentage points above the measured one; measured number inside the range.
By their numbers in this assay, from the lowest: compounds 1, 3, 4 and 2 (each within the scatter of the next, the first and the last beyond it).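

Rearranging the same atom counts within the chlorine-bearing group on the sulfonyl sulfur gives a number 10 percentage points lower from compound 2 to compound 4 (within the scatter), so in this assay the two arrangements cannot be told apart. Replacing 5-(1,2-oxazol-3-yl)thiophen-2-yl with the new group gives a number 8 percentage points higher from compound 3 to compound 4 (within the scatter), so these two cannot be separated either, while replacing 4-(tert-butyl)phenyl gives a number 11 percentage points higher from compound 1 to compound 4 (beyond the scatter) and does show a difference. No supporting data explain these results. From the compounds shown here alone, whether an amine or a methoxy group in place of the chlorine would preserve this inhibition remains open.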